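This account rests on a few compounds, and the source may have more. Where it says the series, first, only, none or still open, it means among the compounds named here.

Measured in a physicochemical assay for lipophilicity, in phosphate buffer, measured as octanol-water partition, with a stated time of 24 h; on this read-out higher numbers stand for higher lipophilicity and lower numbers for lower lipophilicity:

compound 1, `Cc1ccc(Oc2ccc(/C=N\NC(=O)c3ccncc3)cc2)cc1`: 3.65
compound 2, `O=C1Nc2ccccc2/C1=N\NC(=O)c1ccncc1`: 1.12

Of the two compounds measured in this assay, compound 1 gives the higher number, with 3.65. Compound 2 sits lower, with 1.12, and the gap between the two lies beyond the scatter of repeated measurements. The two structures differ in many places at once, so the gap is not tied to any single change.

Compound 3, `O=C(N/N=C\c1ccc(Oc2ccc(Br)cc2)cc1)c1ccncc1`, has not yet been measured in this assay. It differs from compound 1 in one place: bromo in place of methyl on an aromatic carbon. Among the compounds with values here, no measured pair shows this exact change, so the size of the step rests on expectation alone. The exchange of one heavy atom for one heavy atom, without any ring, donor, acceptor or charge entering or leaving, is expected to move the number only a little, if at all, and rather upward than downward. The expected step from compound 1 to compound 3 is a number 0.30 log units higher from compound 1 to compound 3 (within the scatter). Compound 3 is therefore estimated at 3.95, within a range from 3.6 to 4.3.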

Compound 3, partition coefficient: 4.03
Compound 3: the middle estimate sits 0.08 log units below what was measured, and the stated range covers the measured number.
By their numbers in this assay, from the lowest: compound 2; then compound 1; then compound 3.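

Within the data shown here, compound 3 gives the first step in this assay that can be tied to a single place: bromo in place of methyl on an aromatic carbon, para to a large group, gives a number 0.38 log units higher from compound 1 to compound 3 (beyond the scatter) while the rest of the structure stays the same. The position therefore responds to this change, since replacing one heavy atom with one heavy atom, with no ring, hydrogen-bond donor, hydrogen-bond acceptor or net charge entering or leaving, is enough to carry the number past the usual scatter, though only modestly. Nothing at hand speaks to the cause of this step.

The compounds shown leave open how other groups at this same position, such as chloro, an amine, a carboxylic acid or a longer chain, would read in this assay and whether any of them would move the number further in either direction. As far as these compounds go, they also hold only this one case of the exchange, so it remains open whether bromo in place of methyl would give a step of similar size elsewhere on the shared core.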